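Dropping the fluorine from compound 2: a para-to-hydrogen step

The source may hold more compounds than are shown below. What is called first, only, known or untested is meant among the compounds shown, and "the series" means these compounds.

Measured so far:
compound 1, `COc1cc(NC(=O)CCCCCCNC(=O)C(O)(O)C(F)(F)F)cc(OC)c1OC`, 14100 nM
compound 2, `O=C(CCCCCCNC(=O)C(O)(O)C(F)(F)F)Nc1ccc(F)cc1`, 7570 nM
compound 3, `COc1ccc(-c2cnc(NC(=O)CCCCCCNC(=O)C(O)(O)C(F)(F)F)s2)cc1`, 930 nM

All three compounds share a chain that carries a trifluoromethyl-bearing hydrate at one end and an anilide-type amide at the other, and they were tested in a functional assay on HCT-116 cells (Homo sapiens) for inhibition, read by colorimetric assay, with a stated time of 3 days; a lower number here means a stronger inhibitor, a higher number a weaker inhibitor. Compound 2 gives 7570 nM, the second-highest of the three numbers. Its nearest neighbour is compound 1, which gives 14100 nM; the two are within the usual scatter of each other, so nothing can be said about their order. The furthest is compound 3, which gives 930 nM, a gap well beyond the scatter, so compound 3 is the stronger inhibitor of that pair.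

The next compound, compound 4, `O=C(CCCCCCNC(=O)C(O)(O)C(F)(F)F)Nc1ccccc1`, differs from compound 2 in one place: hydrogen in place of fluoro on an aromatic carbon. Among the measured compounds shown here, no pair of measured compounds shows this kind of change, so no step size is known from the data. A single fluorine on the aromatic ring is a small change, and the expectation is a step of no more than the scatter, if anything a slightly higher number. Compound 4 is therefore estimated to give 9500 nM in this assay, with a range of 4000 nM to 22000 nM, which would mean an expected step of a 1.3-fold higher number from compound 2 to compound 4 (0.10 log units; within the scatter).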

Compound 4, half-maximal inhibitory concentration: 9140 nM
Compound 4: the middle estimate sits 1.0-fold (0.02 log units) above what was measured, within the range that was stated.
By their numbers in this assay, from the lowest: compound 3; then compounds 2, 4 and 1 (each within the scatter of the next).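

In this assay, among the compounds shown here, the change from 4-fluorophenyl to phenyl gives the first direct reading of a single change, and it comes to a 1.2-fold higher number from compound 2 to compound 4 (0.08 log units; within the scatter). The fluoro group on this aromatic carbon, para to a large group, can therefore be exchanged for hydrogen without a step that can be told apart from the scatter, and compound 2 and compound 4 cannot be put in any order. The earlier compounds could not show this, since no two of them differed in only one place, and nothing at hand gives a reason for the outcome.

Going by these compounds, whether an amine or a carboxylic acid on this same aromatic carbon would shift the number beyond the scatter remains open, as does whether a longer chain would alter the reading for compound 4. Compound 1 and compound 3 each differ from compound 4 in more than one place, so the separate contribution of any one feature of those compounds cannot be traced from the compounds shown.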